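The compounds below may be only part of what the source reports. "The series", "measured", "known", "first", "only" and "open" are said of these compounds alone.

Measured in a functional assay on A20 cells (Mus musculus) for inhibition, with stated times of 1 h, 16 h and 24 h; a higher number here means a weaker inhibitor, a lower number a stronger inhibitor:
- compound 1 `N#CCNC(=O)[C@@H]1CC(F)(F)C[C@H]1C(=O)N1CCOCC1` gives 925 nM
- compound 2 `CC(C)(C#N)NC(=O)[C@@H]1C[C@@H](S(=O)(=O)c2ccccc2)C[C@H]1C(=O)N1CCOCC1` gives 43 nM
- compound 3 `N#CC1(NC(=O)[C@@H]2C[C@@H](S(=O)(=O)c3ccccc3)C[C@H]2C(=O)N2CCOCC2)CC1` gives 12 nM

Compound 3 has the lowest number of the three, so it is the strongest inhibitor measured so far. The next candidate, compound 4 `N#CC1(NC(=O)[C@@H]2C[C@@H](S(=O)(=O)c3ccccc3)C[C@H]2C(=O)N2CCOCC2)CCC1`, replaces its 1-cyanocyclopropyl on the amide-type nitrogen with 1-cyanocyclobutyl: 1-cyanocyclobutyl in place of 1-cyanocyclopropyl on an amide-type nitrogen.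

Compound 1 differs from the others in more than one place, so it offers little guidance here. Among the measured compounds shown here, only one measured step changes this same position, namely a 3.6-fold lower number from compound 2 to compound 3 (0.55 log units; beyond the scatter), where 1-cyanocyclopropyl replaced 1-cyano-1-methylethyl. That step was modest, and it says nothing directly about enlarging the ring, since no ring-size comparison has been measured yet. For the measured compounds named here, a modest change of similar size therefore seems the most reasonable expectation, tilted cautiously toward a weaker inhibitor in this assay because compound 3 at 12 nM is the lowest value so far.

The expected change is a 2.1-fold higher number from compound 3 to compound 4 (0.32 log units; beyond the scatter) in this estimate.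

For compound 4 the estimated value is 25 nM, with an expected range from 8 nM to 80 nM as the outcome.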

Compound 4, half-maximal inhibitory concentration: 236 nM
For compound 4 the middle estimate is 9.4-fold (0.97 log units) below the measured one; measured number above the stated range.
By their numbers in this assay, from the lowest: compound 3; then compound 2; then compound 4; then compound 1.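

In this assay this position proves highly sensitive to ring size: moving from the three-membered to the four-membered ring gives a 20-fold higher number from compound 3 to compound 4 (1.29 log units; beyond the scatter) and this large step outweighs the earlier 3.6-fold lower number from compound 2 to compound 3 (0.55 log units; beyond the scatter) at the same nitrogen. Having a ring here is not enough for a stronger inhibitor, as 1-cyanocyclobutyl in place of the open-chain 1-cyano-1-methylethyl gives a 5.5-fold higher number from compound 2 to compound 4 (0.74 log units; beyond the scatter) and so goes the opposite way to 1-cyanocyclopropyl. Nothing available explains why the four-membered ring weakens inhibition so much.

As far as these compounds go, whether the number keeps rising with a still larger ring, such as 1-cyanocyclopentyl, remains open. From the compounds shown here alone, it is also open whether the same ring-size effect would hold with a methylsulfonyl group in place of the phenylsulfonyl group on the shared core.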